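Moving from a Fluorophenyl to a Chlorophenyl Group

The source may report more compounds than this note shows. Statements on the series, on what has been measured and on what is new or still open speak of the compounds shown alone.

Of the compounds shown here, three sharing one core have been measured in an assay on isolated protein for binding affinity to Equilibrative nucleoside transporter 1 (Homo sapiens); on this read-out higher numbers stand for weaker inhibition and lower numbers for stronger inhibition. Compound 1 `OC[C@H]1O[C@@H](n2cnc3c(Sc4ccccc4)ncnc32)[C@H](O)[C@@H]1O` gives 91200 nM, compound 2 `OC[C@H]1O[C@@H](n2cnc3c(CSc4c(F)cccc4Cl)ncnc32)[C@H](O)[C@@H]1O` gives 1510 nM, and compound 3 `OC[C@H]1O[C@@H](n2cnc3c(CSc4ccccc4F)ncnc32)[C@H](O)[C@@H]1O` gives 355 nM, the lowest of the three. The step of a 260-fold lower number from compound 1 to compound 3 (2.41 log units; beyond the scatter) was large, while the step of a 4.3-fold lower number from compound 2 to compound 3 (0.63 log units; beyond the scatter) was modest. Compound 4 `OC[C@H]1O[C@@H](n2cnc3c(CSc4cccc(Cl)c4)ncnc32)[C@H](O)[C@@H]1O` differs from compound 3 in one place: 3-chlorophenyl in place of 2-fluorophenyl on a sulfur. Among the compounds with values here, no measured step covers this exact exchange. Within the data shown here, the only hint is that compound 2, which also carries a chloro group, gave the higher number in this assay. A small rise is therefore expected, as the step of a 1.8-fold higher number from compound 3 to compound 4 (0.26 log units; within the scatter). Compound 4 is estimated at 650 nM, with a range from 150 nM to 2800 nM.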

Compound 4, half-maximal inhibitory concentration: 282 nM
The estimate for compound 4 lay 2.3-fold (0.36 log units) above the measured number; the measured number falls inside the stated range.
By their numbers in this assay, from the lowest: compounds 4 and 3 (each within the scatter of the next); then compound 2; then compound 1.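

In this assay, a chloro group on the ring does not by itself go with a higher number: swapping 2-fluorophenyl for 3-chlorophenyl on the sulfur leaves the result within the scatter (a 1.3-fold lower number from compound 3 to compound 4 (0.10 log units; within the scatter)). Compound 4 also sits clearly apart from the 2-chloro-6-fluorophenyl compound (a 5.4-fold lower number from compound 2 to compound 4 (0.73 log units; beyond the scatter)) and keeps the large distance from the shared phenylsulfanyl starting point (a 320-fold lower number from compound 1 to compound 4 (2.51 log units; beyond the scatter)). No measurement here explains these differences. Still open, as far as these compounds go, is whether a plain phenyl on the sulfur, or a ring carrying an amine or a carboxylic acid, would stay in this range.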